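Replacing a Cyanophenyl with a Chlorophenyl: Expected Cytotoxicity

The source may report more compounds than this note shows. Statements on the series, on what has been measured and on what is new or still open speak of the compounds shown alone.

Compound 2 `N#Cc1ccc(-n2nc(-c3ccc(C(F)(F)F)cc3O)nc2-c2ccccc2O)cc1` was tested in a functional assay on PC-12 cells (Rattus norvegicus) for cytotoxicity, read by MTT assay, with stated times of 2 h and 24 h, tested at 10 uM (a lower number here means a weaker effect, a higher number a stronger effect of the compound at the concentration tested), where compound 2 gives 98.9%. Among the compounds with values here, of the two numbers known so far, compound 2 stands lowest; its only neighbour is compound 1 `CC(C)c1ccc(-n2nc(-c3ccc(C(F)(F)F)cc3O)nc2-c2ccccc2O)cc1`, which in this assay gives 108%, and the step of a number 9.1 percentage points lower from compound 1 to compound 2 (within the scatter) lies within the scatter. Compound 3 `Oc1cc(C(F)(F)F)ccc1-c1nc(-c2ccccc2O)n(-c2ccccc2Cl)n1` has not yet been measured. It differs from compound 2 in one place: 2-chlorophenyl in place of 4-cyanophenyl on an aromatic nitrogen. Within the data shown here, the single measured step also altered the group carried on that aromatic nitrogen, and it produced no change beyond the scatter, so the same is expected here. The expected step of a number 1.1 percentage points higher from compound 2 to compound 3 (within the scatter) is therefore small in either direction. For compound 3 the estimated value in this assay is 100%, with a range from 80% to 120%.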

Compound 3, a percentage reported as activity, at one concentration (the size of the read-out at that concentration, not a potency): 102%
Compound 3: middle estimate off by 2 percentage points, on the low side; the range from low to high includes it.
By their numbers in this assay, from the lowest: compounds 2, 3 and 1 (each within the scatter of the next).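

Compound 1 and compound 2 carry 4-isopropylphenyl and 4-cyanophenyl on the aromatic nitrogen, so their substituents share the same numbered place on the phenyl ring, whereas compound 3 carries 2-chlorophenyl. In this assay, this replacement gives two readings (a number 3.1 percentage points higher from compound 2 to compound 3 (within the scatter); a number 6 percentage points lower from compound 1 to compound 3 (within the scatter)). The three groups on this nitrogen therefore give values within the scatter of one another, even though the substituent's numbered place and its identity both differ in compound 3. Nothing measured here explains this closeness. Still open, from the compounds shown here alone, is whether a phenyl ring bearing an amine or a carboxylic acid would also fall within the scatter. The same question applies to a cyclohexyl ring or a longer alkyl chain in place of the phenyl ring on this nitrogen.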